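A few compounds are considered here, and "the series" means these few. Any claim that something is new, unique, unknown or untested is made for them only; others in the source may bear on it.

Measured compounds:
Compound 1 `O=c1c([C@@H]2C[C@H](c3ccccc3)ON2c2ccccc2)coc2ccc(F)cc12` gives 54700 nM in a functional assay on THP-1 cells (Homo sapiens) for inhibition, read by sulforhodamine B assay, with a stated time of 48 h; a higher number here means a weaker inhibitor, a lower number a stronger inhibitor.
Compound 2 `Cc1ccc2occ([C@@H]3C[C@H](c4ccccc4)ON3c3ccccc3)c(=O)c2c1` gives only a limit, > 60000 nM, in this assay.
Compound 3 `Cc1ccc2occ([C@@H]3C[C@H](OCC(C)C)ON3c3ccccc3)c(=O)c2c1` gives 21500 nM in this assay.

Among the measured compounds shown here, compound 2 stands at the top of the series as it is known so far: its result in this assay is a limit of the assay, not a number, and it is the one value that sits at the limit of > 60000 nM in this assay, at which 1 of the 3 values shown sits. Compound 1 and compound 2 differ by methyl in place of fluoro on an aromatic carbon, and the step of an at least 1.0-fold higher number from compound 1 to compound 2 (0.04 log units; that floor lies within the scatter) stays within the scatter. For the measured compounds named here, compound 3 is the one member with a clearly stronger reading, the step of an at least 2.7-fold lower number from compound 2 to compound 3 (0.44 log units; beyond the scatter) being beyond the scatter.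

Compound 4 `O=c1c([C@@H]2C[C@H](c3ccccc3)ON2c2ccccc2)coc2ccc(Br)cc12` differs from compound 2 by bromo in place of methyl on an aromatic carbon. Going by the values given here, the only measured step that bears on this is an at least 1.0-fold higher number from compound 1 to compound 2 (0.04 log units; that floor lies within the scatter), an exchange at the same aromatic carbon between a halogen and methyl, and it produced no movement beyond the scatter. A second halogen-for-methyl exchange at that carbon is therefore expected to give no step beyond the scatter in this assay, with a real chance that compound 4 again reports only a limit. For compound 4 the expected step is an at least 1.0-fold lower number from compound 2 to compound 4 (0.01 log units; that floor lies within the scatter). Compound 4 is estimated at 58000 nM, within 25000 nM to 140000 nM.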

Compound 4, half-maximal inhibitory concentration: 60000 nM
The estimate for compound 4 lay 1.0-fold (0.01 log units) below the measured number, within the range that was stated.
By their numbers in this assay, from the lowest: compound 3; then compounds 1 and 4 (each within the scatter of the next).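

In this assay bromo in place of fluoro on this aromatic carbon gives a 1.1-fold higher number from compound 1 to compound 4 (0.04 log units; within the scatter) as a step that can be read directly, so these two halogens cannot be told apart here with phenyl on the saturated ring carbon. Among the compounds shown here, the step between methyl and bromo, given as a number no higher from compound 2 to compound 4 (the limit leaves the size open), cannot be read, because compound 2 is held only as a limit of the assay: the limit of > 60000 nM in this assay, at which 1 of the 4 values shown sits. Among the steps that can be read, changes at this aromatic carbon still stay within the scatter, while the one step beyond it remains the change on the saturated ring carbon (an at least 2.7-fold lower number from compound 2 to compound 3 (0.44 log units; beyond the scatter)).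

The compounds shown carry only fluoro, methyl and bromo at this aromatic carbon, so how an amine or a carboxylic acid there would read in this assay stays open. Also open, on these data alone, are whether isobutoxy on the saturated ring carbon gives a similar step with fluoro or bromo on the aromatic carbon, and how a longer chain would read in place of isobutoxy.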